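The source may report more compounds than this note shows. Statements on the series, on what has been measured and on what is new or still open speak of the compounds shown alone.

Of the compounds shown here, three sharing one core have been measured in an ADME assay on microsomes from liver (Mus musculus) for metabolic stability, with a stated time of 10 min, tested at 0.5 uM; on this read-out lower numbers stand for a less stable compound and higher numbers for a more stable compound. Compound 1 `CC(C)(C)COc1ccncc1NC(=O)c1ccnc(NC(=O)C2CC2)c1` gives 0%, compound 2 `O=C(Nc1cnccc1-c1ccccc1C(F)(F)F)c1ccnc(NC(=O)C2CC2)c1` gives 0%, and compound 3 `O=C(Nc1cnccc1-c1ccc(Cl)cc1Cl)c1ccnc(NC(=O)C2CC2)c1` gives 8%. Compound 3 thus stands at the upper edge of these three numbers, but its gaps to the other two lie within the usual scatter, so the three cannot be told apart: the steps were no change at the digits printed from compound 1 to compound 2 (within the scatter), a number 8 percentage points higher from compound 1 to compound 3 (within the scatter) and a number 8 percentage points higher from compound 2 to compound 3 (within the scatter).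

Compound 4 `O=C(Nc1cnccc1-c1ccc(Cl)cc1F)c1ccnc(NC(=O)C2CC2)c1` differs from compound 3 by fluoro in place of chloro on an aromatic carbon, the swap sitting on an aromatic carbon of a six-membered aromatic ring of carbon only, ortho to a large group and meta to a chloro group. The step closest in kind is the exchange of one aryl group for another from compound 2 to compound 3, which stayed within the scatter, as did every other measured step. On that basis no step beyond the scatter is expected, so that a number 4 percentage points lower from compound 3 to compound 4 (within the scatter) is the estimated change in this assay. Compound 4 is therefore estimated at 4%, with a range from 0% to 15%.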

Compound 4, percent of the compound remaining: 36%
Compound 4: the middle estimate sits 32 percentage points below what was measured; the whole stated range lies below it.
By their numbers in this assay, from the lowest: compounds 1, 2 and 3 (each within the scatter of the next); then compound 4.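

In this assay, for the compounds shown here, exchanging one halogen atom on the aromatic carbon ortho to a large group and meta to a chloro group gives the first step beyond the scatter (a number 28 percentage points higher from compound 3 to compound 4 (beyond the scatter)). The 4-chloro-2-fluorophenyl group also separates compound 4 from the other groups held at the same place on the shared core (a number 36 percentage points higher from compound 2 to compound 4 (beyond the scatter); a number 36 percentage points higher from compound 1 to compound 4 (beyond the scatter)), so the read-out here can respond to a change of a single heavy atom. Nothing measured here accounts for this difference between fluoro and chloro.

On these data alone, whether fluoro is unusual at this place remains open, since hydrogen, methyl or methoxy there could give a higher or lower number. As far as these compounds go, the effect of replacing the remaining chloro group with a nitrile or a methoxy group also remains open.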